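A few compounds are considered here, and "the series" means these few. Any claim that something is new, unique, unknown or untested is made for them only; others in the source may bear on it.

Working notes on the series, read in an ADME assay; a lower number here means that the compound disappears faster, a higher number that the compound lasts longer. Going by the values given here, compound 1 `COc1ccc(C[S+]([O-])c2ncccc2C(=O)Nc2ccncc2)c(OC)c1` gives 0.84 h, and compound 2 `COc1ccc(C[S+]([O-])c2ncccc2C(=O)Nc2ccncc2)c(OCCO)c1` gives 1.78 h, the higher of the two numbers so far. Compound 3 `COCOCCOc1cc(OC)ccc1C[S+]([O-])c1ncccc1C(=O)Nc1ccncc1` differs from compound 2 by one change, methoxymethyl in place of hydrogen on an oxygen on a saturated carbon, which turns 2-hydroxyethyl into 2-(methoxymethoxy)ethyl.

Among the compounds with values here, only one measured step bears on this: a 2.1-fold higher number from compound 1 to compound 2 (0.33 log units; beyond the scatter), a modest change that placed hydroxymethyl on a saturated chain carbon bound to an oxygen on an aromatic ring. Compound 3 keeps that chain, but the hydrogen on its hydroxy is replaced. Within the data shown here, no measured compound carries a replacement on that oxygen, so the guide is a loose one. With only a 2.1-fold higher number from compound 1 to compound 2 (0.33 log units; beyond the scatter) to go on, a partial return toward compound 1 is expected, meaning a small fall that stays within the scatter. The expected change is a 1.5-fold lower number from compound 2 to compound 3 (0.17 log units; within the scatter). For compound 3 the estimate is 1.2 h, with an expected range from 0.6 h to 2.4 h.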

Compound 3, half-life: 2.75 h
Beside the measured number, compound 3's estimate is 2.3-fold (0.36 log units) below it; measured number above the stated range.
By their numbers in this assay, from the lowest: compound 1; then compounds 2 and 3 (each within the scatter of the next).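

At this position, on an oxygen on a saturated carbon, methoxymethyl in place of hydrogen gives a 1.5-fold higher number from compound 2 to compound 3 (0.19 log units; within the scatter) in this assay and so 2-hydroxyethyl and 2-(methoxymethoxy)ethyl cannot be told apart in this read-out. With the hydroxy capped, the chain still gives a 3.3-fold higher number from compound 1 to compound 3 (0.52 log units; beyond the scatter) and this step lies beyond the scatter, so among these compounds a free hydroxy at the chain end is not needed for a clear separation from the methoxy of compound 1. No available data explain how either chain acts on this read-out.

Open, going by these compounds, is how far the chain end tolerates other groups: a terminal amine or a carboxylic acid on the same chain could show whether the separation from compound 1 holds with a very different end group. Also open, on these data alone, is whether chain length matters, which a longer chain ending in hydroxy would test against compound 2 and compound 3 on the shared core.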